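Swapping the Propylphenyl Amide for a Nitrophenyl Amide

The compounds below may be only part of what the source reports. "The series", "measured", "known", "first", "only" and "open" are said of these compounds alone.

Measured compounds:
- compound 1 `COc1ccc(OCC(=O)Nc2cccc(NC(=O)c3ccc(N(C)C)cc3)c2)cc1OC` — in an assay on isolated protein for inhibition of Rho-associated protein kinase 2 (Homo sapiens), read by scintillation counting, radiometric assay and 33P incorporation, with a stated time of 40 min, in the presence of a further agent that is not named here (a higher number here means a weaker inhibitor, a lower number a stronger inhibitor), compound 1 gives > 10000 nM, a limit of the assay
- compound 2 `CN(C)c1ccc(C(=O)Nc2cccc(NC(=O)COc3ccc4occc(=O)c4c3)c2)cc1` — in this assay compound 2 gives > 10000 nM, a limit of the assay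
- compound 3 `CCCc1ccc(C(=O)Nc2cccc(NC(=O)COc3ccc4c(=O)ccoc4c3)c2)cc1` — in this assay compound 3 gives 14 nM

Going by the values given here, compound 3 is the only compound of the three for which a number, rather than a limit, was obtained; the other two sit at the limit of > 10000 nM in this assay, at which 2 of the 3 values shown sit. Among the compounds with values here, the one measured step between compounds differing in a single place, a step that the two limits leave unreadable from compound 1 to compound 2, runs between two limits and so cannot be read as a size; it also concerns the group on an oxygen on a saturated carbon, not the amide end of the shared core.

Compound 4 `O=C(COc1ccc2c(=O)ccoc2c1)Nc1cccc(NC(=O)c2cccc([N+](=O)[O-])c2)c1` differs from compound 3 by 3-nitrophenyl in place of 4-propylphenyl on a carbonyl carbon. Within the data shown here, no measured step touches this carbonyl-attached group, so nothing in the numbers says how large the step should be or in which direction. The expectation therefore rests on compound 3 alone, whose value 14 nM is the only anchor, and the range must be wide.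

Compound 4 is estimated at 80 nM, between 10 nM and 1500 nM, an expected step of a 5.7-fold higher number from compound 3 to compound 4 (0.76 log units; beyond the scatter).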

Compound 4, half-maximal inhibitory concentration: 41 nM
Compound 4: the middle estimate sits 2.0-fold (0.29 log units) above what was measured, and the stated range covers the measured number.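

Going by these compounds alone, replacing 4-propylphenyl with 3-nitrophenyl on a carbonyl carbon whose other neighbour is an amide-type nitrogen gives a 2.9-fold higher number from compound 3 to compound 4 (0.47 log units; beyond the scatter), the first step at this place that can be read as a size. The two groups have the same count of heavy atoms and each holds one six-membered aromatic ring of carbon only, yet their side chains differ, so this place on the shared core accepts more than a single kind of group while still giving a measured number in this assay: compound 4 gives 41 nM. Nothing shown here accounts for why the number moves with this change.

This one step changes both the group on the ring and the name's ring position, so it leaves open how much belongs to the nitro group itself and how much to that position, which 4-nitrophenyl or 3-propylphenyl would separate. From the compounds shown here alone, how an amine, a carboxylic acid or a longer chain such as butyl would read at this same place also remains open.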